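Adding a benzyloxy group to compound 2

The source may report more compounds than this note shows. Statements on the series, on what has been measured and on what is new or still open speak of the compounds shown alone.

In a functional assay on a cell-free system (plasma, Homo sapiens) for inhibition, with Plasma (Rattus norvegicus) as the target (on this read-out higher numbers stand for weaker inhibition and lower numbers for stronger inhibition), compound 1 (`O=c1cc(N2CCNCC2)oc2ccccc12`) gives 56000 nM and compound 2 (`O=c1cc(N2CCNCC2)c2ccccc2o1`) gives 49000 nM as its number, two values within the usual scatter of each other. Compound 3 (`O=c1cc(N2CCNCC2)c2c(OCc3ccccc3)cccc2o1`) gives 187000 nM as its number, so compound 2 sits level with compound 1 at the stronger end of these three, and neither of the two can be ranked above the other.

Compound 4 (`O=c1cc(N2CCNCC2)c2ccc(OCc3ccccc3)cc2o1`) has not been measured yet. Its difference from compound 2 is benzyloxy in place of hydrogen on an aromatic carbon, and that group is also what separates compound 3 from compound 2, though on a different aromatic carbon. Among the measured compounds shown here, this is the only measured step of its kind, and it gave a 3.8-fold higher number from compound 2 to compound 3 (0.58 log units; beyond the scatter) as a modest loss of inhibition. A single step at another carbon is thin evidence, so the size carries real doubt. Even so, a higher number is expected in this assay for the new compound, probably by somewhat less than that step. The expected step is a 2.2-fold higher number from compound 2 to compound 4 (0.35 log units; beyond the scatter) as a rough estimate. Compound 4 is estimated at 110000 nM with an expected range from 45000 nM to 260000 nM as its likely number.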

Compound 4, half-maximal inhibitory concentration: 16300 nM
The estimate for compound 4 lay 6.7-fold (0.83 log units) above the measured number; measured number outside the range, below it.
By their numbers in this assay, from the lowest: compound 4; then compounds 2 and 1 (each within the scatter of the next); then compound 3.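

In this assay, putting benzyloxy in place of hydrogen has no single direction of effect: on the aromatic carbon that is meta to a fused ring and para to a fused ring it brings a 3.0-fold lower number from compound 2 to compound 4 (0.48 log units; beyond the scatter), while on a different aromatic carbon it brings a 3.8-fold higher number from compound 2 to compound 3 (0.58 log units; beyond the scatter). The entering group is identical in the two steps and only its place differs, so for this pair the carbon that carries the benzyloxy decides whether inhibition gets stronger or weaker, and the first step alone could not have shown that a gain was possible. No measurement here explains why the two carbons part ways.

On these data alone, it remains open whether the gain needs the whole benzyloxy group, with its six-membered aromatic ring, or whether a smaller group such as methoxy or hydroxy on the same carbon would do as well. Also open, as far as these compounds go, is how an amine or a longer chain would behave at this carbon, and whether benzyloxy there would bring a similar gain on the core of compound 1.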